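This account rests on a few compounds, and the source may have more. Where it says the series, first, only, none or still open, it means among the compounds named here.

Measured in an ADME assay on L6 cells (Rattus norvegicus) for cytotoxicity, read by resazurin assay, with a stated time of 72 h; on this read-out higher numbers stand for an effect only at larger amounts of compound and lower numbers for an effect already at smaller amounts:
- Compound 1 `CCOC(=O)C1=C(C)N/C(=C/c2cn(-c3ccc(C(F)(F)F)cc3)nn2)C1=O`: 14000 nM
- Compound 2 `CC1=C(C(=O)OCc2ccccc2)C(=O)/C(=C\c2cc(C)n(-c3ccccc3C(F)(F)F)c2C)N1`: 57000 nM

Compound 2 stands higher of the two, and the gap to compound 1 lies beyond the usual scatter of repeated measurements. These two compounds differ in more than one place, so their gap says nothing about any single group.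

Compound 3 `CC1=C(C(=O)NCCO)C(=O)/C(=C\c2cc(C)n(-c3ccccc3C(F)(F)F)c2C)N1` keeps the core of compound 2 and differs from it in one place: (2-hydroxyethyl)amino in place of benzyloxy on a carbonyl carbon. In words, (2-hydroxyethyl)amino replaces benzyloxy on a carbonyl carbon, so benzyloxycarbonyl becomes (2-hydroxyethyl)carbamoyl. Going by the values given here, no measured pair shows this change, which leaves its size and direction uncertain. Among the compounds with values here, the only close reference is compound 2 at 57000 nM. A small rise in this assay is expected, and it may not exceed the scatter, although a fall cannot be ruled out. The estimated change is a 1.6-fold higher number from compound 2 to compound 3 (0.20 log units; within the scatter). For compound 3, the estimated value is 90000 nM, with an expected range of 30000 nM to 200000 nM.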

Compound 3, half-maximal effective concentration: 49000 nM
For compound 3 the middle estimate is 1.8-fold (0.26 log units) above the measured one; measured number inside the range.
By their numbers in this assay, from the lowest: compound 1; then compounds 3 and 2 (each within the scatter of the next).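

In this assay, going by these compounds alone, the first step that changes only one place gives a 1.2-fold lower number from compound 2 to compound 3 (0.07 log units; within the scatter), so compound 2 and compound 3 cannot be told apart on this read-out. The earlier compounds shown here could not show this, since compound 1 and compound 2 differ in more than one place. Here, the change from benzyloxycarbonyl to (2-hydroxyethyl)carbamoyl on the carbonyl carbon removes the six-membered aromatic ring of benzyloxy and brings in a group with no ring and more hydrogen-bond donors, yet it leaves no difference beyond the scatter in this one pair, and nothing measured here offers an explanation for that.

Still open, going by these compounds, is whether other groups on this carbonyl carbon, such as a carboxylic acid or a longer chain ending in an amine, would also stay within the scatter of compound 2. Also open, on these data alone, is which structural difference lies behind the gap between compound 1 and compound 2, and whether (2-hydroxyethyl)amino would behave the same way on the core of compound 1.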